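The source may report more compounds than this note shows. Statements on the series, on what has been measured and on what is new or still open speak of the compounds shown alone.

Measured so far:
- compound 1 `C=CS(=O)(=O)N1CCN(c2ncnc3ccc(-c4ccccc4)cc23)CC1`: 47900 nM
- compound 2 `C=CS(=O)(=O)N1CCN(c2ncnc3sc(-c4ccc(OC)cc4)cc23)CC1`: 29900 nM

In a functional assay on MDA-MB-231 cells (Homo sapiens) for antiproliferative activity, read by MTT assay, with a stated time of 48 h (a lower number here means a stronger inhibitor, a higher number a weaker inhibitor), compound 1 gives 47900 nM and compound 2 gives 29900 nM. The two numbers lie within the usual scatter of each other, so compound 2 is not set apart from compound 1 on these figures; both compounds are weak in this assay. Among the compounds with values here, no step between two measured compounds that differ in one place is available, so the effect of changing the group on the five-membered ring of the core has not been seen.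

Compound 3 `C=CS(=O)(=O)N1CCN(c2ncnc3sc(-c4cccs4)cc23)CC1` carries the change (thiophen-2-yl in place of 4-methoxyphenyl on an aromatic carbon). Within the data shown here, with no comparable step to go by, the expected step of a 1.2-fold higher number from compound 2 to compound 3 (0.08 log units; within the scatter) is taken to be small, most likely none beyond the scatter, with a slight lean towards a weaker number given that compound 2 is already weak at 29900 nM. Compound 3 is therefore estimated at 36000 nM in this assay, with a range from 12000 nM to 110000 nM.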

Compound 3, half-maximal inhibitory concentration: 34100 nM
The estimate for compound 3 lay 1.1-fold (0.02 log units) above the measured number, and the stated range covers the measured number.
By their numbers in this assay, from the lowest: compounds 2, 3 and 1 (each within the scatter of the next).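

In this assay, within the data shown here, thiophen-2-yl in place of 4-methoxyphenyl, on an aromatic carbon next to the ring sulfur, gives a 1.1-fold higher number from compound 2 to compound 3 (0.06 log units; within the scatter), the first single-place comparison. At this position, then, a five-membered aromatic ring with 1 hetero atom and a six-membered aromatic ring of carbon only are not separated by the read-out, and both compounds remain weak. No measurement at hand accounts for this flat result.

Still open, going by these compounds, is how an amine or a carboxylic acid on this carbon would read in place of an aromatic ring, and whether any group here moves the number beyond the scatter. The role of the core also remains unresolved, as compound 1 and compound 2 differ in more than one place.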